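The compounds below may be only part of what the source reports. "The series", "measured", "known", "first", "only" and "open" are said of these compounds alone.

Series notes. The reference point is compound 1, `Cc1ccc2c(c1C)CN(CCCN(C)C)CC2c1ccccc1`. Going by the values given here, in a functional assay on A2780 cells (Homo sapiens) for antiproliferative activity (on this read-out higher numbers stand for weaker inhibition and lower numbers for stronger inhibition), compound 1 gives 3240 nM, and within this set it is the only compound with a number at all. Compound 2, `Cc1ccc2c(c1C)CN(S(C)(=O)=O)CC2c1ccccc1`, has no result reported in this assay: "not determined" (no result reported). Compound 3, `Cc1ccc2c(c1C)CN(C(N)=O)CC2c1ccccc1`, likewise has no result reported: "not determined" (no result reported). So compound 1 stands alone, and no step between two measured compounds exists to show how large a change on the amine nitrogen in the ring moves this read-out.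

The compound under consideration is compound 4, `Cc1ccc2c(c1C)CN(C(=O)N1CCCCC1)CC2c1ccccc1`. Relative to compound 1 the change is (piperidin-1-yl)carbonyl in place of 3-(dimethylamino)propyl on an amine nitrogen in a ring. Without any measured step to lean on, the size of the move is open in both directions; an expected weakening is set down here, with a wide margin, as the step from compound 1 to compound 4 of a 2.5-fold higher number from compound 1 to compound 4 (0.39 log units; beyond the scatter). For compound 4 the expected value in this assay is therefore 8000 nM, with a range from 2000 nM to 30000 nM.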

Compound 4, half-maximal inhibitory concentration: 2830 nM
Compound 4: the middle estimate sits 2.8-fold (0.45 log units) above what was measured; low and high end bracket the measured number.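

In this assay, going by these compounds alone, the exchange on the amine nitrogen in the ring gives a 1.1-fold lower number from compound 1 to compound 4 (0.06 log units; within the scatter) and so provides the first readable step at this position, one that lies within the scatter. The two groups are far from alike, since (piperidin-1-yl)carbonyl brings a six-membered non-aromatic ring and a carbonyl that 3-(dimethylamino)propyl lacks, yet the read-out does not separate them. Nothing measured here offers an explanation for this result.

The steps involving compound 2 and compound 3 cannot be read, so a single step is all that describes this position. Going by these compounds, whether the read-out moves at all with a different group on this nitrogen remains open, for instance with a simple methyl or with a longer chain ending in a carboxylic acid.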